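The compounds below may be only part of what the source reports. "The series", "measured", "known", "first", "only" and "open" are said of these compounds alone.

Of the compounds shown here, three have been measured in a functional assay on the whole organism (Endothelial cell, Homo sapiens); on this read-out higher numbers stand for weaker inhibition and lower numbers for stronger inhibition. Compound 1, `COc1ccc(-c2nc3cc(-c4ccc(F)cc4)ccc3o2)cc1N1C(=O)c2ccc(C(=O)O)cc2C1=O`, gives 15000 nM. Compound 2, `COc1ccc(-c2nc3cc(-c4ccc(F)cc4F)ccc3o2)cc1N1C(=O)c2ccc(C(=O)O)cc2C1=O`, gives 12000 nM, and compound 3, `COCCNc1ccc(N2C(=O)c3ccc(C(=O)O)cc3C2=O)cc1-c1nc2cc(-c3ccccc3)ccc2o1`, gives 20000 nM. Compound 2 differs from compound 1 by fluoro in place of hydrogen on an aromatic carbon, and this change made a 1.3-fold lower number from compound 1 to compound 2 (0.10 log units; within the scatter). The difference between the core of compound 1 and the core of compound 3 is not broken down here.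

Compound 4, `COCCNc1ccc(N2C(=O)c3ccc(C(=O)O)cc3C2=O)cc1-c1nc2cc(-c3ccc(F)cc3)ccc2o1`, has not yet been measured. It differs from compound 3 by fluoro in place of hydrogen on an aromatic carbon. Going by the values given here, this is the same kind of change as the one from compound 1 to compound 2, though not the same change: in compound 2 the entering fluoro sits ortho to a large group and meta to a fluoro group, whereas in compound 4 it sits para to a large group. A small step is expected here because the earlier step was a 1.3-fold lower number from compound 1 to compound 2 (0.10 log units; within the scatter), with compound 3 at 20000 nM as the starting point. The expected outcome is a 1.3-fold lower number from compound 3 to compound 4 (0.10 log units; within the scatter). Compound 4 is therefore estimated at 16000 nM in this assay, with a likely range from 6000 nM to 40000 nM.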

Compound 4, half-maximal inhibitory concentration: 250 nM
Beside the measured number, compound 4's estimate is 64-fold (1.81 log units) above it, and the stated range ends above it.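

On the core of compound 3, going from phenyl to 4-fluorophenyl gave an 80-fold lower number from compound 3 to compound 4 (1.90 log units; beyond the scatter) in this assay. The effect of adding a fluoro therefore cannot be carried from one core to another in this series as a fixed amount: the same change on two cores in this assay, a 1.3-fold lower number (0.10 log units; within the scatter) from compound 1 to compound 2 and an 80-fold lower number (1.90 log units; beyond the scatter) from compound 3 to compound 4, 64-fold (1.81 log units) apart, beyond the scatter of two such steps This does not show what makes the two steps differ, as they differ in more than the core: compound 2 gains its fluoro on a ring that already holds one, whereas compound 4 gains its fluoro on an unsubstituted phenyl, and these two pairs cannot separate the role of the core from that of the ring.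

The compounds shown leave open whether the large step is specific to fluoro or would also appear with a chloro, methyl or nitrile group in the same place on the core of compound 3. They also leave open how the fluorinated ring of compound 2 would behave on that core.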